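The source may report more compounds than this note shows. Statements on the series, on what has been measured and on what is new or still open speak of the compounds shown alone.

Measured in a functional assay on K562 cells (Homo sapiens) for antiproliferative activity, read by CCK-8 assay, with a stated time of 72 h; a lower number here means a stronger inhibitor, a higher number a weaker inhibitor:
- compound 1 `Cc1cc(Nc2cc(N3CCN(C)CC3)nc(Nc3ccc([N+](=O)[O-])cc3)n2)n[nH]1`: 137 nM
- compound 2 `COc1cccc(Nc2nc(Nc3cc(C)[nH]n3)cc(N3CCN(C)CC3)n2)c1`: 509 nM
- compound 3 `Cc1cc(Nc2cc(N3CCN(C)CC3)nc(Nc3cccc(Cl)c3)n2)n[nH]1`: 97.2 nM

Compound 3 stands at 97.2 nM. It lies within the scatter of compound 1, as a 1.4-fold lower number from compound 1 to compound 3 (0.15 log units; within the scatter) shows. Compound 2 is clearly separated from it, with a 5.2-fold lower number from compound 2 to compound 3 (0.72 log units; beyond the scatter).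

Compound 4 `COc1ccc(Nc2nc(Nc3cc(C)[nH]n3)cc(N3CCN(C)CC3)n2)cc1` has not yet been measured. It carries 4-methoxyphenyl in place of 3-chlorophenyl on a nitrogen on an aromatic ring.

The closest evidence is the pair of compound 2 and compound 3, where chloro replaces methoxy on an aromatic carbon. Read in reverse, that step suggests a higher number when a methoxy group comes in. However, the methoxy group of compound 4 sits elsewhere on the ring, and no measured pair compares 3-methoxyphenyl with 4-methoxyphenyl directly. Compound 1 adds some caution, since its 4-nitrophenyl group gives 137 nM, and a 3.7-fold higher number from compound 1 to compound 2 (0.57 log units; beyond the scatter) shows that the 3-methoxyphenyl group of compound 2 does not match it. A modest rise is therefore the likeliest outcome, though the evidence is thin. The expected step is a 3.6-fold higher number from compound 3 to compound 4 (0.56 log units; beyond the scatter). For compound 4 the estimated value is 350 nM, with an expected range from 120 nM to 1000 nM.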

Compound 4, half-maximal inhibitory concentration: 271 nM
Beside the measured number, compound 4's estimate is 1.3-fold (0.11 log units) above it; the measured number falls inside the stated range.
By their numbers in this assay, from the lowest: compounds 3, 1, 4 and 2 (each within the scatter of the next, the first and the last beyond it).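

In this assay, 4-methoxyphenyl in place of 3-chlorophenyl on this nitrogen gives a weaker inhibitor (a 2.8-fold higher number from compound 3 to compound 4 (0.45 log units; beyond the scatter)), so a clear cost of methoxy in place of chloro is now seen with the methoxy group in a second location on the ring. Going by these compounds alone, the first direct comparison of the two methoxy-bearing rings, 4-methoxyphenyl and 3-methoxyphenyl, shows no difference that can be told from the usual scatter (a 1.9-fold lower number from compound 2 to compound 4 (0.27 log units; within the scatter)), so these two compounds do not show that the location of the methoxy group matters. Methoxy in place of nitro on the same ring location likewise gives no separable change (a 2.0-fold higher number from compound 1 to compound 4 (0.30 log units; within the scatter)), which leaves 4-nitrophenyl and 4-methoxyphenyl indistinguishable here, even though only the former stays within the scatter of the 3-chlorophenyl compound.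

Nothing available here explains why these groups differ. Still open, going by these compounds, is whether 4-chlorophenyl would behave like 3-chlorophenyl, and how a ring carrying an amine or a carboxylic acid at this place would fare.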